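This account rests on a few compounds, and the source may have more. Where it says the series, first, only, none or still open, it means among the compounds named here.

Measured compounds:
- compound 1 `NS(=O)(=O)c1ccc(Nc2ncc(F)c(Nc3nc4ccccc4s3)n2)cc1`, which in a functional assay on MCF7 cells (Homo sapiens) for antiproliferative activity, read by MTT assay, with a stated time of 48 h (on this read-out lower numbers stand for stronger inhibition and higher numbers for weaker inhibition), gives > 50000 nM, a limit of the assay
- compound 2 `Cc1cnc(Nc2ccc(S(N)(=O)=O)cc2)nc1Nc1nc2ccccc2s1`, which in this assay gives > 50000 nM, a limit of the assay
- compound 3 `Cc1cnc(Nc2ccc(S(N)(=O)=O)cc2)nc1Nc1nc2ccc(F)cc2s1`, which in this assay gives > 50000 nM, a limit of the assay

All three measured compounds sit at the limit of > 50000 nM in this assay, at which 3 of the 3 values shown sit, so compound 2 stands at a limit and not at a number, level with the other two. The step that the two limits leave unreadable from compound 1 to compound 2 and the step that the two limits leave unreadable from compound 2 to compound 3 are therefore both unreadable, and they concern other positions of the shared core in any case.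

Compound 4 `Cc1cnc(Nc2ccc(C(C)C)cc2)nc1Nc1nc2ccccc2s1` differs from compound 2 by isopropyl in place of sulfamoyl on an aromatic carbon. Among the measured compounds shown here, none of the measured steps touches this position or this pair of groups, so there is no measured step that bears on it, and the size and direction of the change in this assay cannot be read from what has been measured. Compound 2 itself gives only a limit, so the step is expected to be unreadable whenever compound 4 also returns a limit.

On that basis compound 4 is estimated at 30000 nM, with a range from 3000 nM to 100000 nM, and the step from compound 2 is expected as an at least 1.6-fold lower number from compound 2 to compound 4 (0.22 log units; that floor lies within the scatter).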

Compound 4, half-maximal inhibitory concentration: > 50000 nM
Compound 4 gave a limit, no number; the forecaster's own chance of this, stated with the estimate: 55%; middle value at least 1.6-fold (0.22 log units) from the limit.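

In this assay compound 4 gives > 50000 nM, a limit and not a number. No step from compound 2 to compound 4 can be read, because both compounds sit at the same limit: the limit of > 50000 nM in this assay, at which 4 of the 4 values shown sit.

The compounds shown leave open whether exchanging sulfamoyl for isopropyl changes antiproliferative activity at all, and how far any of them lies beyond that limit.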